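Compound 1 and its double-bond isomer, compound 4

The source may hold more compounds than are shown below. What is called first, only, known or untested is meant among the compounds shown, and "the series" means these compounds.

In a functional assay on HT-29 cells (Homo sapiens) for inhibition, read by sulforhodamine B assay, with a stated time of 48 h (on this read-out higher numbers stand for weaker inhibition and lower numbers for stronger inhibition), compound 1 `CCNC(=O)Nc1ccc(/C=C\c2cc(C)cc(C)c2)cc1` gives 11000 nM, the highest number of the three measured compounds. Compound 2 `Cc1cc(C)cc(/C=C\c2ccc(N3CCNC3=O)cc2)c1` gives 8.4 nM, and compound 3 `COc1cc(/C=C\c2ccc(N3CCNC3=O)cc2)cc(OC)c1OC` gives 1.7 nM. Among the compounds with values here, the one measured step is a 1300-fold lower number from compound 1 to compound 2 (3.12 log units; beyond the scatter), with 2-oxoimidazolidin-1-yl in place of (ethylcarbamoyl)amino on an aromatic carbon. It is large, but it lies at a different place from the change considered here.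

Compound 4 `CCNC(=O)Nc1ccc(/C=C/c2cc(C)cc(C)c2)cc1` differs from compound 1 as follows: the two compounds have the same atoms and bonds and differ only in configuration as drawn: 1 of 1 stereo elements differ; a double bond is drawn Z in compound 1 and E in compound 4. A double bond is drawn Z in compound 1 and E in compound 4. Within the data shown here, all three measured compounds are drawn Z, so the data hold no measured step for this change and give no direct size for it. Only a modest move towards a higher number in this assay is expected, and a result within the scatter would be no surprise. The expected step is a 1.5-fold higher number from compound 1 to compound 4 (0.16 log units; within the scatter). Compound 4 is estimated at 16000 nM, with an expected range of 4000 nM to 60000 nM.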

Compound 4, half-maximal inhibitory concentration: > 20000 nM
Compound 4 was reported as a limit (the forecaster's own chance of this, stated with the estimate: 30%); middle value at least 1.2-fold (0.09 log units) away from the limit.
By their numbers in this assay, from the lowest: compound 3; then compound 2; then compound 1. At a limit, above all of these: compound 4.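

In this assay compound 4 is reported as > 20000 nM, which is a limit and not a number. This gives the series its first reading on the configuration of the double bond, and it has only a floor: an at least 1.8-fold higher number from compound 1 to compound 4 (0.25 log units; that floor lies within the scatter), so the data neither establish a real loss on going from Z to E nor set an upper bound on one. Any difference between the two compounds can be assigned to this one element alone, with the rest of the structure unchanged: the fact that compounds 1 and 4 differ only in the configuration as drawn

Open, going by these compounds, is how the same change from Z to E behaves on the 2-oxoimidazolidin-1-yl compounds, compound 2 and compound 3, whose low numbers would leave far more room to read its size. Also open, on these data alone, is how a primary amine or a carboxylic acid would fare in place of (ethylcarbamoyl)amino on the Z core.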